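Fluoro for Methyl on the Pendant Phenyl Ring

The source may report more compounds than this note shows. Statements on the series, on what has been measured and on what is new or still open speak of the compounds shown alone.

Measured compounds:
compound 1, `COc1cc2c(Oc3ccc(NC(=O)c4cc(-c5ccccc5C)ccn4)cc3F)ccnc2cc1OCCCN1CCCC1`: 420 nM
compound 2, `COc1cc2c(Oc3ccc(NC(=O)c4cc(-c5ccccc5F)ccn4)cc3F)ccnc2cc1OCCCN1CCCC1`: 140 nM
compound 3, `COc1cc2c(Oc3ccc(NC(=O)c4nccc(-c5ccc(C)cc5)n4)cc3F)ccnc2cc1OCCCN1CCCCC1`: 230 nM

Three compounds were tested in a functional assay on NCI-H460 cells (Homo sapiens) for cytotoxicity, read by MTT assay, with a stated time of 72 h; on this read-out higher numbers stand for weaker inhibition and lower numbers for stronger inhibition. In this assay compound 1 gives 420 nM, compound 2 gives 140 nM and compound 3 gives 230 nM.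

Compound 1 and compound 2 differ in one place, (fluoro in place of methyl on an aromatic carbon), and this change made a step of a 3.0-fold lower number from compound 1 to compound 2 (0.48 log units; beyond the scatter).

Compound 4, `COc1cc2c(Oc3ccc(NC(=O)c4nccc(-c5ccc(F)cc5)n4)cc3F)ccnc2cc1OCCCN1CCCCC1`, is not yet measured. It stands to compound 3 as compound 2 stands to compound 1: fluoro in place of methyl on an aromatic carbon. The difference between the core of compound 3 and the core of compound 1 is not broken down here. The two changes are of the same kind but not the same: in compound 1 the exchanged group sits ortho to a large group, in compound 3 it sits para to a large group.

The values of compound 3 and compound 2 lie within the scatter of each other, so nothing can be said of their order. Going by the values given here, because the one measured instance of this change, a 3.0-fold lower number from compound 1 to compound 2 (0.48 log units; beyond the scatter), reached beyond the scatter, the step from compound 3 to compound 4 is expected to be a 2.1-fold lower number from compound 3 to compound 4 (0.32 log units; beyond the scatter), in the same direction but held somewhat smaller as the surroundings of the place differ. Compound 4 is therefore estimated at 110 nM, expected between 50 nM and 260 nM.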

Compound 4, half-maximal inhibitory concentration: 240 nM
Compound 4: middle estimate off by 2.2-fold (0.34 log units), on the low side; low and high end bracket the measured number.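

In this assay, fluoro in place of methyl on the core of compound 3 gave a 1.0-fold higher number from compound 3 to compound 4 (0.02 log units; within the scatter) and so left no readable difference, whereas the same exchange on the core of compound 1 had given a step beyond the scatter. The change therefore did not carry over from one core to the other with its size intact, and the two instances differ by more than repeated measurement would explain: the same change on two cores in this assay, a 3.0-fold lower number (0.48 log units; beyond the scatter) from compound 1 to compound 2 and a 1.0-fold higher number (0.02 log units; within the scatter) from compound 3 to compound 4, 3.1-fold (0.50 log units) apart, beyond the scatter of two such steps. What this does not show is the reason for the difference, since the two pairs differ both in their core and in the place of the exchange, with the group in compound 3 and compound 4 sitting para to a large group and the group in compound 1 and compound 2 sitting elsewhere on the pendant phenyl ring, and two pairs cannot separate these factors.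

The compounds shown leave open whether 4-methylphenyl to 4-fluorophenyl would give a step beyond the scatter on the core of compound 1, and whether the exchange at the other place would do so on the core of compound 3. They also leave open how chloro, methoxy or a nitrile would read at either place on either core.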